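A few compounds are considered here, and "the series" means these few. Any claim that something is new, unique, unknown or untested is made for them only; others in the source may bear on it.

Notes on the series built on the shared core of compound 1 `Nc1ncnc2c1ncn2CC(O)C(=O)OCCO`, read in a functional assay on PRK cells (Oryctolagus cuniculus) for cytotoxicity; on this read-out higher numbers stand for lower toxicity in this test and lower numbers for higher toxicity in this test. Compound 1 gives only a limit here, > 400 ug/mL; this rests on (the limit of > 400 ug/mL in this assay, at which 1 of the 3 values shown sits). Compound 2 `CCCCCCCCOC(=O)C(O)Cn1cnc2c(N)ncnc21` gives 100 ug/mL in this assay. Compound 3 `CCCOC(=O)C(O)Cn1cnc2c(N)ncnc21` gives 100 ug/mL in this assay and so stands level with compound 2 at the digits shown. Against compound 1 only a limit is available. The measured steps read: an at least 4.0-fold lower number from compound 1 to compound 2 (0.60 log units; beyond the scatter); an at least 4.0-fold lower number from compound 1 to compound 3 (0.60 log units; beyond the scatter); no change at the digits printed from compound 2 to compound 3 (within the scatter).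

Compound 4 `CCC(C)OC(=O)C(O)Cn1cnc2c(N)ncnc21` is not yet measured. Against compound 3 the change is methyl in place of hydrogen on a saturated chain carbon bound to an oxygen next to a carbonyl group and a saturated chain carbon. The step that bears on it is the one with pentyl leaving for hydrogen on the same saturated chain, where no change at the digits printed from compound 2 to compound 3 (within the scatter). A single methyl entering on a saturated chain carbon bound to an oxygen next to a carbonyl group and a saturated chain carbon is a smaller alteration of that same chain, so no step beyond the scatter is expected in this assay. Compound 4 is therefore expected at 100 ug/mL, within 50 ug/mL to 200 ug/mL. The step that this estimate means is no change at the digits printed from compound 3 to compound 4 (within the scatter), expected to stay within the scatter.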

Compound 4, minimum cytotoxic concentration: > 400 ug/mL
Compound 4: only a limit was reported (the forecaster's own chance of this, stated with the estimate: 10%); middle value at least 4.0-fold (0.60 log units) away from the limit.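

The single methyl on a saturated chain carbon bound to an oxygen next to a carbonyl group and a saturated chain carbon moves the number where the change of chain length did not: in this assay the result is an at least 4.0-fold higher number from compound 3 to compound 4 (0.60 log units; beyond the scatter) and, with sec-butyl in place of octyl, an at least 4.0-fold higher number from compound 2 to compound 4 (0.60 log units; beyond the scatter) on the same read-out. Among compound 2, compound 3 and compound 4, then, a straight chain of either length goes with the lower number and lower reading of this test's tolerance, whereas propyl to sec-butyl at this one carbon goes with lower toxicity in this test. Compound 1 and compound 4 both stand only as limits, so the step between them cannot be read: the limit of > 400 ug/mL in this assay, at which 2 of the 4 values shown sit.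

On these data alone, what stays open is whether the shift belongs to branching at this carbon or to the sec-butyl group as a whole; an isopropyl or a tert-butyl group on the same oxygen would separate the two. As far as these compounds go, how a longer branched chain or an amine on the chain would read in this assay also stays open, and the limit on compound 4 leaves the true size of the step unknown.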